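A few compounds are considered here, and "the series" means these few. Any claim that something is new, unique, unknown or untested is made for them only; others in the source may bear on it.

In a functional assay on K562 cells (Homo sapiens) for cytotoxicity, read by MTT assay, with a stated time of 48 h (a lower number here means a stronger inhibitor, a higher number a weaker inhibitor), compound 1 (`O=C(CN[C@H]1CCN(S(=O)(=O)Cc2ccccc2)C1)N1CCN(Cc2cccc(C(F)(F)F)c2)CC1`) gives 3600 nM and compound 2 (`O=C(CN[C@H]1CCN(S(=O)(=O)Cc2ccccc2)C1)N1CCN(Cc2c(Cl)cccc2Cl)CC1`) gives 28400 nM as its reading. Within the data shown here, that is the higher of the only two numbers available, which makes compound 2 the weaker inhibitor of the pair. Compound 3 (`COc1cccc(CN2CCN(C(=O)CN[C@H]3CCN(S(=O)(=O)Cc4ccccc4)C3)CC2)c1`) has not yet been measured. It differs from compound 2 by a single swap (3-methoxyphenyl in place of 2,6-dichlorophenyl on a saturated chain carbon bound to an amine nitrogen in a ring): 3-methoxyphenyl in place of 2,6-dichlorophenyl on a saturated chain carbon bound to an amine nitrogen in a ring. Among the measured compounds shown here, only one measured step touches that same place, and it is modest but beyond the scatter: 2,6-dichlorophenyl came in for 3-(trifluoromethyl)phenyl and the number rose (a 7.9-fold higher number from compound 1 to compound 2 (0.90 log units; beyond the scatter)). Since compound 3 gives up the 2,6-dichlorophenyl, a move toward lower numbers is expected. However, 3-methoxyphenyl is a different group from the one in compound 1, and a single step is thin evidence, so a somewhat smaller change is the expectation (a 3.6-fold lower number from compound 2 to compound 3 (0.55 log units; beyond the scatter)). For compound 3 the estimated value in this assay is 8000 nM with an expected range from 2800 nM to 23000 nM in repeated measurements.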

Compound 3, half-maximal inhibitory concentration: 60800 nM
Beside the measured number, compound 3's estimate is 7.6-fold (0.88 log units) below it; measured number above the stated range.
By their numbers in this assay, from the lowest: compound 1; then compound 2; then compound 3.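

Among these compounds, the new reading shows that giving up 2,6-dichlorophenyl does not by itself lower the number at this position: in this assay, the change to 3-methoxyphenyl gives a 2.1-fold higher number from compound 2 to compound 3 (0.33 log units; beyond the scatter), the opposite direction from the one the earlier step suggested. Compounds 1 and 3 differ only in the group on an aromatic carbon, and a 17-fold higher number from compound 1 to compound 3 (1.23 log units; beyond the scatter) is the largest gap in the set, so the choice between trifluoromethyl and methoxy there matters greatly, with compound 1 the strongest inhibitor of the three and compound 3 the weakest. No measurement offered here explains why these groups rank in this order.

Among the compounds shown here, with only three groups at this position, the order cannot be extended to other groups, and a plain phenyl, 3-chlorophenyl or a ring carrying a nitrile could fall anywhere relative to them. As far as these compounds go, it also remains open whether a ring holding an amine or a carboxylic acid would bring the number below that of compound 1, and whether this order would hold on a longer chain between the ring and the amine nitrogen.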